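The compounds below may be only part of what the source reports. "The series", "measured", "known", "first", "only" and "open" are said of these compounds alone.

Measured in a functional assay on PC-3 cells (Homo sapiens) for antiproliferative activity, read by MTT assay, with a stated time of 24 h (a lower number here means a stronger inhibitor, a higher number a weaker inhibitor), so far:
- compound 1 (`CCn1c(C(=O)NCCC(=O)OC)ccc1C(CC)(CC)c1ccc(OCS(=O)(=O)c2ccccc2)c(C)c1`): 40400 nM
- compound 2 (`CCn1c(C(=O)NC(C)(C)CO)ccc1C(CC)(CC)c1ccc(OCS(=O)(=O)c2ccccc2)c(C)c1`): 9850 nM

Compound 2 holds the lower of the two numbers, and its gap to compound 1 lies beyond the scatter. Compound 3 (`CCn1c(C(=O)N[C@H](CO)CCO)ccc1C(CC)(CC)c1ccc(OCS(=O)(=O)c2ccccc2)c(C)c1`) has not yet been measured. It carries 3-hydroxy-1-(hydroxymethyl)propyl in place of 1-(hydroxymethyl)-1-methylethyl on an amide-type nitrogen and is otherwise unchanged. For the measured compounds named here, one measured step bears on this change: a 4.1-fold lower number from compound 1 to compound 2 (0.61 log units; beyond the scatter) is modest and also alters the group on that amide-type nitrogen. Going by the values given here, a single step shows no trend, and no measured compound carries the entering group. Since compound 2 at 9850 nM is only the lower of two values, a small rise is expected rather than a further fall, with a size no greater than that of the measured step. The expected step is a 1.6-fold higher number from compound 2 to compound 3 (0.21 log units; within the scatter) in this assay and may not clear the scatter. For compound 3 the estimated value is 16000 nM with an expected range from 5000 nM to 45000 nM in this series.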

Compound 3, half-maximal inhibitory concentration: 12100 nM
Estimate against measurement, compound 3: 1.3-fold (0.12 log units) above; the measured number falls inside the stated range.
By their numbers in this assay, from the lowest: compounds 2 and 3 (each within the scatter of the next); then compound 1.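

In this assay the step of a 1.2-fold higher number from compound 2 to compound 3 (0.09 log units; within the scatter) shows that this amide-type nitrogen tolerates 3-hydroxy-1-(hydroxymethyl)propyl in place of 1-(hydroxymethyl)-1-methylethyl without a readable separation, although the two groups differ in heavy atoms, in hydrogen-bond donors and acceptors, and in the defined stereocentre of the entering group. The step of a 3.3-fold lower number from compound 1 to compound 3 (0.52 log units; beyond the scatter) stands beyond the scatter, as does a 4.1-fold lower number from compound 1 to compound 2 (0.61 log units; beyond the scatter), so among these three compounds both hydroxyl-bearing groups give lower numbers than the 2-(methoxycarbonyl)ethyl group of compound 1, and this no longer rests on a single pair. No supporting evidence is available to account for this difference between the hydroxyl-bearing groups and the ester-bearing group.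

The compounds shown leave open how an amine, a carboxylic acid or a longer chain ending in hydroxyl on this amide-type nitrogen would read in this assay, and so whether the number can move well away from those of compound 2 and compound 3. They also leave open what the defined stereocentre contributes, as the opposite configuration of 3-hydroxy-1-(hydroxymethyl)propyl does not stand among them.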